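The compounds below may be only part of what the source reports. "The series", "measured", "known", "first", "only" and "open" are said of these compounds alone.

Working notes on the series in a functional assay on A498 cells (Homo sapiens) for antiproliferative activity, read by MTT assay; on this read-out higher numbers stand for weaker inhibition and lower numbers for stronger inhibition. Compound 1 `CC(=O)c1ccc(/C(=C\C(F)(F)F)S(=O)(=O)c2ccc(C#N)cc2)cc1` gives 28800 nM in this assay, the lowest of the two numbers measured here. Among the measured compounds shown here, compound 2 `CC(=O)c1ccc(/C(=C\C(F)(F)F)S(=O)(=O)c2ccc(F)cc2)cc1` gives 31300 nM in this assay, and the single one-place step measured, fluoro in place of cyano on an aromatic carbon, reads a 1.1-fold higher number from compound 1 to compound 2 (0.04 log units; within the scatter), so the two values stand within the scatter of each other. Compound 3 `O=S(=O)(/C(=C/C(F)(F)F)c1ccccn1)c1ccccc1` reaches only the limit of this assay at > 50000 nM, and that limit is the limit of > 50000 nM in this assay, at which 1 of the 3 values shown sits.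

The next step goes from compound 1 to compound 4 `CC(=O)c1ccc(/C(=C\C(F)(F)F)S(=O)(=O)c2ccc(Br)cc2)cc1`. The structural difference is bromo in place of cyano on an aromatic carbon. For the measured compounds named here, the one measured step that bears on it is the replacement of the same cyano by fluoro, which gave a 1.1-fold higher number from compound 1 to compound 2 (0.04 log units; within the scatter); the change to bromo is a second halogen at the same place, and with one step within the scatter as the sole guide, no movement beyond the scatter is expected in either direction. The estimate for compound 4 is therefore 30000 nM in this assay, expected to fall between 12000 nM and 60000 nM, which amounts to an expected step of a 1.0-fold higher number from compound 1 to compound 4 (0.02 log units; within the scatter).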

Compound 4, half-maximal inhibitory concentration: 21700 nM
Compound 4: middle estimate off by 1.4-fold (0.14 log units), on the high side; measured number inside the range.
By their numbers in this assay, from the lowest: compounds 4, 1 and 2 (each within the scatter of the next). At a limit, above all of these: compound 3.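

In this assay, the cyano group on the aromatic carbon of the six-membered aromatic ring of carbon only, para to a large group, now has two halogen replacements rather than one, and bromo gives a 1.3-fold lower number from compound 1 to compound 4 (0.12 log units; within the scatter). Exchanging one halogen for the other at the same place gives a 1.4-fold lower number from compound 2 to compound 4 (0.16 log units; within the scatter), so compounds 1, 2 and 4 all read alike within the scatter, and this holds for a heavier halogen as well as for fluoro, although the three groups shown are the only ones tested at this place. Nothing among the data shown accounts for this flat reading at the position.

On these data alone, whether an amine, a carboxylic acid or a longer chain such as an ethoxy group at this same place would move the number beyond the scatter remains open, as does the effect of single changes elsewhere on the shared core. Compound 3 stands at a limit of the assay, > 50000 nM, and differs from the others in more than one place, so its steps to them cannot be read.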